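Compound 4 and the Limit of a Stability Assay

The compounds below may be only part of what the source reports. "The series", "measured", "known", "first", "only" and "open" are said of these compounds alone.

Measured in an ADME assay on Jejunum (Mus musculus, strain C57BL/6) for metabolic stability, read by HPLC, with a stated time of 12 h; a higher number here means that the compound lasts longer, a lower number that the compound disappears faster:
Compound 1 `O=C(O)[C@@H](CO)NC(=O)[C@H]1C[C@H](O)CN1`: > 12 h
Compound 2 `O=C(N[C@H](CO)C(=O)O)[C@@H]1C[C@H](O)CN1`: > 12 h
Compound 3 `O=C(O)[C@H](CO)NC(=O)[C@H]1C[C@@H](O)CN1`: > 12 h

In this assay, compound 1 stands at > 12 h, which is a limit and not a number. The whole series is defined by the limit of > 12 h in this assay, at which 3 of the 3 values shown sit. From compound 1 to compound 4 `O=C(N[C@H](CO)C(=O)O)[C@@H]1C[C@@H](O)CN1`, the change is this: the two compounds have the same atoms and bonds and differ only in configuration as drawn: 2 of 3 stereo elements differ; a stereocentre at a saturated ring carbon is drawn R in compound 1 and S in compound 4; a stereocentre at a saturated ring carbon is drawn S in compound 1 and R in compound 4. For the measured compounds named here, three steps bear on it: a step that the two limits leave unreadable from compound 1 to compound 2, a step that the two limits leave unreadable from compound 1 to compound 3 and a step that the two limits leave unreadable from compound 2 to compound 3. Each is a change of configuration alone, and none has a readable size. No step beyond the scatter is therefore expected in either direction, and the estimated step is a step that the limit leaves unreadable from compound 1 to compound 4. For compound 4, the expected value is 15 h, with an estimated range from 10 h to 24 h.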

Compound 4, half-life: 0.39 h
Beside the measured number, compound 4's estimate is 38-fold (1.59 log units) above it; the measured number lies below the stated range.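

Configuration alone can decide the outcome in this assay, which the unreadable steps among compounds 1, 2 and 3 could not show. Inverting one stereocentre at a saturated ring carbon gives an at least 30-fold lower number from compound 2 to compound 4 (1.48 log units; beyond the scatter), the sharpest evidence here: the fact that compounds 2 and 4 differ only in the configuration as drawn Two inverted stereocentres give an at least 30-fold lower number from compound 1 to compound 4 (1.48 log units; beyond the scatter) and an at least 30-fold lower number from compound 3 to compound 4 (1.48 log units; beyond the scatter), so compound 4 stands apart from the other three compounds.

From the compounds shown here alone, how far compounds 1, 2 and 3 differ among themselves stays open, since the steps among them cannot be read. Going by these compounds, whether the same inversion would matter with a methyl ester in place of the carboxylic acid also stays open.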